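Fluoro removal from the 3-fluorophenyl compound

The compounds below may be only part of what the source reports. "The series", "measured", "known", "first", "only" and "open" are said of these compounds alone.

- compound 1 `COc1ccc(S(=O)(=O)N2CCc3cccc(-c4ccco4)c32)cc1`: 62.5 nM
- compound 2 `COc1ccc(S(=O)(=O)N2CCc3cccc(-c4cccc(F)c4)c32)cc1`: 119 nM

In a functional assay on HT-29 cells (Homo sapiens) for inhibition, with a stated time of 72 h (a lower number here means a stronger inhibitor, a higher number a weaker inhibitor), compound 2, at 119 nM, lies within the scatter of compound 1, so the two numbers give no order. The next structure is compound 3 `COc1ccc(S(=O)(=O)N2CCc3cccc(-c4ccccc4)c32)cc1`, with hydrogen in place of fluoro on an aromatic carbon, 3-fluorophenyl to phenyl (hydrogen in place of fluoro on an aromatic carbon). For the measured compounds named here, no measured step isolates this change. Going by the values given here, the only step available is a 1.9-fold higher number from compound 1 to compound 2 (0.28 log units; within the scatter), a swap of furan-2-yl for 3-fluorophenyl, and it stays within the scatter. With so little evidence, no shift beyond the scatter is expected, and the estimated step is a 1.2-fold lower number from compound 2 to compound 3 (0.08 log units; within the scatter), with no direction firmly implied. For compound 3 the expected value in this assay is 100 nM, with an estimated range of 45 nM to 220 nM.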

Compound 3, half-maximal inhibitory concentration: 96.5 nM
For compound 3 the middle estimate is 1.0-fold (0.02 log units) above the measured one; measured number inside the range.
By their numbers in this assay, from the lowest: compounds 1, 3 and 2 (each within the scatter of the next).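

In this assay hydrogen in place of fluoro gives a 1.2-fold lower number from compound 2 to compound 3 (0.09 log units; within the scatter) and so isolates this single change on the six-membered aromatic ring, showing that the number at this place does not depend on the fluoro. Phenyl in place of furan-2-yl gives a 1.5-fold higher number from compound 1 to compound 3 (0.19 log units; within the scatter) and, unlike the earlier comparison, this swap carries no fluoro, so the two ring types stay within the scatter of each other with or without it. Nothing at hand gives a cause for these steps.

Open, from the compounds shown here alone, is whether an amine, a carboxylic acid or a longer alkyl chain on this aromatic carbon, in place of the phenyl, would move the number beyond the scatter. Also open, going by these compounds, is whether chloro, methoxy or trifluoromethyl in place of the fluoro would do so.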